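Quinone in Place of Hydroquinone on a Pyrazole Core

The source may report more compounds than this note shows. Statements on the series, on what has been measured and on what is new or still open speak of the compounds shown alone.

The series is tested in a functional assay on cells (Cancer cell lines, Homo sapiens) for cytotoxicity, read by sulforhodamine B assay, with a stated time of 48 h; a lower number here means a stronger inhibitor of growth, a higher number a weaker inhibitor of growth. Compound 1 `Oc1ccc(O)c(-c2cc(-c3ccccc3)nn2-c2ccccc2)c1` gives 28500 nM, compound 2 `Oc1ccc(O)c(-c2cc(-c3ccc(Cl)cc3)nn2-c2ccccc2)c1` gives 5750 nM, and compound 3 `NS(=O)(=O)c1ccc(-n2nc(-c3ccc(Cl)cc3)cc2-c2cc(O)ccc2O)cc1` gives 15100 nM. Among these three, compound 2 has the lowest number: compound 3 comes nearest and compound 1 lies furthest away. The two measured steps, a 5.0-fold lower number from compound 1 to compound 2 (0.70 log units; beyond the scatter) and a 2.6-fold higher number from compound 2 to compound 3 (0.42 log units; beyond the scatter), both concern the outer aryl rings, and both are modest.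

Compound 4 `O=C1C=CC(=O)C(c2cc(-c3ccc(Cl)cc3)nn2-c2ccccc2)=C1` differs from compound 2 in another place: a group of 8 heavy atoms (6 carbon, 2 oxygen; one six-membered non-aromatic ring of carbon only) in place of a group of 8 heavy atoms (6 carbon, 2 oxygen; one six-membered aromatic ring of carbon only), on an aromatic carbon. Neither measured step touches this ring, so neither bears directly on the change; they only show that single substitutions on this core have so far shifted this assay by modest amounts in either direction. Without a measured precedent for exchanging the dihydroxyphenyl for the dione ring, the direction is uncertain, and a step of modest size in either direction, or none beyond the scatter, would fit what the shown steps allow. The expected step is therefore a 1.6-fold lower number from compound 2 to compound 4 (0.22 log units; within the scatter). Compound 4 is thus estimated at 3500 nM in this assay, with a range from 800 nM to 15000 nM.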

Compound 4, concentration for 50% growth inhibition: 42400 nM
Compound 4: middle estimate off by 12-fold (1.08 log units), on the low side; the whole stated range lies below it.
By their numbers in this assay, from the lowest: compound 2; then compounds 3, 1 and 4 (each within the scatter of the next, the first and the last beyond it).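

This is the first change shown at the ring on the aromatic carbon of the five-membered ring, and in this assay it moves the number up, with a 7.4-fold higher number from compound 2 to compound 4 (0.87 log units; beyond the scatter), so the 2,5-dihydroxyphenyl group cannot be exchanged for the dione ring here without a loss of growth inhibition beyond the scatter. For the compounds shown here, the exchange keeps the heavy-atom count and the hydrogen-bond acceptor count but takes the hydrogen-bond donors from 2 to 0 and replaces the aromatic ring with a non-aromatic one, so the single step joins these differences and cannot separate them. Nothing available explains why the number rises with this exchange.

The compounds shown leave open whether a ring carrying methoxy groups or amino groups in place of the two hydroxyl groups would stay aromatic in character and hold the number of compound 2 or move towards that of compound 4. They also leave open whether the same exchange to the dione ring would shift the number by a similar amount on compound 1, without the chloro group, or on compound 3, with its sulfamoyl group.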